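Extending the sulfonyl group of an EP2 agonist

A few compounds are considered here, and "the series" means these few. Any claim that something is new, unique, unknown or untested is made for them only; others in the source may bear on it.

Measured so far:
compound 1, `CC(C)(C)c1ccc(CN(Cc2cccc(OCC(=O)O)c2)S(C)(=O)=O)cc1`, 203 nM
compound 2, `CC(C)(C)c1ccc(CN(Cc2cccc(CCC(=O)O)c2)S(=O)(=O)c2ccc(Cl)cc2)cc1`, "not determined" (no result reported)

Among the measured compounds shown here, compound 1 is the only member of this small set with a number: in a functional assay on HEK293 cells for agonist activity at prostaglandin E2 receptor EP2 subtype (Rattus norvegicus), read by cAMP accumulation (a higher number here means that more compound is needed for the effect, a lower number that less compound is needed), compound 1 gives 203 nM. Compound 2, which carries a chlorophenylsulfonyl group and a propanoic acid chain in place of the oxyacetic acid, is recorded in this assay as "not determined" (no result reported), so it offers no comparison.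

Compound 3, `Cn1ccnc1CS(=O)(=O)N(Cc1ccc(C(C)(C)C)cc1)Cc1cccc(OCC(=O)O)c1`, keeps the core of compound 1 and differs from it in one place: 1-methyl-1H-imidazol-2-yl in place of hydrogen on a saturated chain carbon bound to a sulfonyl sulfur. For the measured compounds named here, since no pair of measured compounds shows what growth on the sulfonyl substituent does here, the direction of the step can only be guessed. The change adds a heteroaromatic ring to a small methylsulfonyl group while leaving the acid and the tert-butylbenzyl arm untouched, and a step close to the scatter, in either direction, seems the most likely outcome. Compound 3 is therefore expected to give 160 nM in this assay, with a plausible range from 40 nM to 650 nM, which means an expected step of a 1.3-fold lower number from compound 1 to compound 3 (0.10 log units; within the scatter).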

Compound 3, half-maximal effective concentration: 58 nM
Compound 3: the middle estimate sits 2.8-fold (0.44 log units) above what was measured; measured number inside the range.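

In this assay, among the compounds shown here, 1-methyl-1H-imidazol-2-yl in place of hydrogen on a saturated chain carbon bound to a sulfonyl sulfur gives a 3.5-fold lower number from compound 1 to compound 3 (0.54 log units; beyond the scatter), the first step in this set that can be read between compounds differing in one place. It shows that the small methylsulfonyl group of compound 1 can be extended to ((1-methyl-1H-imidazol-2-yl)methyl)sulfonyl without any loss in this read-out, and that less compound is then needed for the effect, although the step is modest. Nothing available accounts for this gain, so it stands as an observation about this one change and is not tied to any feature of the entering group.

The compounds shown leave open whether the gain depends on the imidazole itself, since a plain phenyl ring, a pyridine ring, an imidazole without its methyl group or a simple longer alkyl chain on the same carbon would each separate the ring from the mere growth of the substituent. They also leave open how the sulfonyl extension behaves alongside a different acid chain, such as the propanoic acid of compound 2, which offers no number for comparison.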